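This account rests on a few compounds, and the source may have more. Where it says the series, first, only, none or still open, it means among the compounds named here.

Working notes on the series. The shared core carries a side chain on a saturated ring carbon, and three compounds have been measured in a functional assay on HEK293 cells for agonist activity at G-protein coupled receptor 39 (Homo sapiens), read by scintillation proximity assay and inositol phosphate accumulation, with a stated time of 75 min, in the presence of a further agent that is not named here; a higher number here means that more compound is needed for the effect, a lower number that less compound is needed. Compound 1 `Cc1nn(-c2ncnc3nc[nH]c23)c2c1C(OCc1ccc(Cl)cc1Cl)CC(=O)N2` gives 4 nM. Compound 2 `Cc1nn(-c2ncnc3nc[nH]c23)c2c1C(OCc1ccccc1C#N)CC(=O)N2` gives 8 nM. Compound 3 `Cc1nn(-c2ncnc3nc[nH]c23)c2c1C(NC(=O)Cc1cccs1)CC(=O)N2` gives 3 nM. Against compound 1 the difference is a 1.3-fold lower number from compound 1 to compound 3 (0.12 log units; within the scatter); against compound 2 it is a 2.7-fold lower number from compound 2 to compound 3 (0.43 log units; beyond the scatter), so compound 3 is separated beyond the scatter only from compound 2.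

Compound 4 `Cc1nn(-c2ncnc3nc[nH]c23)c2c1C(NC(=O)c1ccccc1)CC(=O)N2` differs from compound 3 by phenyl in place of (thiophen-2-yl)methyl on a carbonyl carbon. Among the measured compounds shown here, no measured step swaps one aromatic ring for another on the carbonyl carbon. The closest comparison is the aryl swap within the side chain, a 2.0-fold higher number from compound 1 to compound 2 (0.30 log units; within the scatter), which stayed within the scatter; the steps that replaced the whole side chain, a 1.3-fold lower number from compound 1 to compound 3 (0.12 log units; within the scatter) and a 2.7-fold lower number from compound 2 to compound 3 (0.43 log units; beyond the scatter), were small or modest. The expectation for this assay is therefore a step of a 1.7-fold higher number from compound 3 to compound 4 (0.22 log units; within the scatter), at most modest and in either direction. Compound 4 is expected to give about 5 nM, with a range of 1.5 nM to 15 nM.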

Compound 4, half-maximal effective concentration: 3 nM
Compound 4: the middle estimate sits 1.7-fold (0.22 log units) above what was measured, and the stated range covers the measured number.
By their numbers in this assay, from the lowest: compounds 3, 4, 1 and 2 (each within the scatter of the next, the first and the last beyond it).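

In this assay, the swap of (thiophen-2-yl)methyl for phenyl on the carbonyl carbon gives no change at the digits printed from compound 3 to compound 4 (within the scatter), so at this carbonyl carbon the two aromatic side chains cannot be told apart. The benzamido side chain also stands where the earlier amide stood against the two benzyloxy side chains, with a 2.7-fold lower number from compound 2 to compound 4 (0.43 log units; beyond the scatter) and a 1.3-fold lower number from compound 1 to compound 4 (0.12 log units; within the scatter), so only compound 2 is separated from the amides, and compound 1 goes against any reading that amides as a group differ from these ethers. Nothing available accounts for the two amides reading alike.

Still open, on these data alone, is whether a longer chain on the carbonyl carbon, or cyclohexyl in place of phenyl, would keep the number in this range. A carboxylic acid on the phenyl ring, or a methyl on the amide nitrogen, would test the limits of this side chain further.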